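Azido in Place of Methylsulfanyl: An Expected Small Step

A few compounds are considered here, and "the series" means these few. Any claim that something is new, unique, unknown or untested is made for them only; others in the source may bear on it.

Compound 2 `CSc1nccc2c1ncn2C1O[C@H](CO)[C@@H](O)[C@H]1O` was tested in a functional assay on EL4 cells (Mus musculus) for inhibition, tested at 100 uM; a higher number here means more inhibition at the concentration tested (going by the name of the read-out), a lower number less inhibition. In this assay compound 2 gives only a limit of < 5% rather than a number. Compound 1 `[N-]=[N+]=Nc1nccc2c1ncn2[C@H]1C[C@H](O)[C@@H](CO)O1`, which carries the azido group on a different sugar, gives 13% in this assay. The picture so far is a modest one, with compound 2 sitting at the limit of < 5% in this assay, at which 1 of the 2 values shown sits.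

Compound 3 `[N-]=[N+]=Nc1nccc2c1ncn2C1O[C@H](CO)[C@@H](O)[C@H]1O` has not yet been measured. It differs from compound 2 by azido in place of methylsulfanyl on an aromatic carbon. Within the data shown here, no measured pair of compounds isolates this change on its own, so the expected step is a number at least 4 percentage points higher from compound 2 to compound 3 (that floor lies within the scatter), a shift that is expected to stay within the usual scatter of this assay. In this assay compound 3 is therefore estimated at 9%, with a range from 0% to 20%, and a fair chance that only a limit is reported again.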

Compound 3, a percentage reported as inhibition, at one concentration (the size of the read-out at that concentration, not a potency): < 5%
Compound 3 gave a limit, no number (the forecaster's own chance of this, stated with the estimate: 35%); at least 4 percentage points between middle value and limit.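

Compound 2 and compound 3 both give only a limit, not a number, so no step can be read between them: the limit of < 5% in this assay, at which 2 of the 3 values shown sit. The compounds shown leave open whether azido in place of methylsulfanyl on an aromatic carbon changes the result in this assay at all.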